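The compounds below may be only part of what the source reports. "The series", "measured", "known", "first", "only" and "open" are said of these compounds alone.

Working notes on the series in a functional assay on HEK293 cells for agonist activity at G-protein coupled receptor 84 (Homo sapiens), read by calcium flux; on this read-out higher numbers stand for larger maximal responses and lower numbers for smaller maximal responses. Of the compounds shown here, two have numbers so far. Compound 1 `CC(C)CCCc1nc(O)cc(O)n1` gives 85.6%. Compound 2 `CCCCCc1nc(O)cc(O)n1` gives 84.9%; the two stand within the scatter of each other, so compound 2 is not set apart from compound 1 on this read-out. Within the data shown here, the single measured step, a number 0.7 percentage points lower from compound 1 to compound 2 (within the scatter), is hydrogen in place of methyl on a saturated chain carbon bound to two saturated chain carbons.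

Compound 3 `CCCCCCCc1nc(O)cc(O)n1` is the next compound, differing from compound 2 by ethyl in place of hydrogen on a saturated chain carbon, five bonds along the chain from an aromatic carbon. Among the measured compounds shown here, the only step that bears on this chain lengthening is the one from compound 1 to compound 2, and it lay within the scatter. On that basis the step from compound 2 to compound 3 is expected to be a number 0.1 percentage points higher from compound 2 to compound 3 (within the scatter) in this assay, not beyond the scatter in either direction. Compound 3 is therefore estimated at 85%, in a range from 74% to 96%.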

Compound 3, largest response reached (reported as percent of maximum), in percent of the reference or control that the assay uses: 103%
Compound 3: middle estimate off by 18 percentage points, on the low side; measured number outside the range, above it.
By their numbers in this assay, from the lowest: compounds 2 and 1 (each within the scatter of the next); then compound 3.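

Ethyl in place of hydrogen on a saturated chain carbon, five bonds along the chain from an aromatic carbon, gives a number 18.1 percentage points higher from compound 2 to compound 3 (beyond the scatter) in this assay, the first step in the series beyond the scatter. Butyl in place of isopropyl on a saturated chain carbon, three bonds along the chain from an aromatic carbon, gives a number 17.4 percentage points higher from compound 1 to compound 3 (beyond the scatter) as well, so the maximal response does move with this chain, which the earlier step within the scatter did not show. No measurement at hand accounts for the rise.

Going by these compounds, whether a longer chain than that of compound 3 raises the response further or lowers it stays open. Also open, on these data alone, is whether an amine or a carboxylic acid in place of the added ethyl would keep the response of compound 3.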